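The compounds below may be only part of what the source reports. "The series", "measured", "known", "first", "only" and "open" are said of these compounds alone.

Compound 3, with structure `CCCC[S+]([O-])c1sc2nc(-c3nccs3)cc(-c3ccc(C(=O)OC)cc3)c2c1N`, is the weakest of the three measured in an assay for inhibition of 15-hydroxyprostaglandin dehydrogenase [NAD(+)] (Homo sapiens), read by fluorescence, with a stated time of 15 min, in the presence of a further agent that is not named here (on this read-out higher numbers stand for weaker inhibition and lower numbers for stronger inhibition), where compound 3 gives 15.1 nM. Its nearest neighbour is compound 1, `CCCC[S+]([O-])c1sc2nc(-c3nccs3)cc(-c3ccc(C(C)(C)O)cc3)c2c1N`, which in this assay gives 3.6 nM; compound 2, `CCCC[S+]([O-])c1sc2nc(-c3nccs3)cc(-c3ccc(CO)cc3)c2c1N`, gives 2.5 nM. The step of a 4.2-fold higher number from compound 1 to compound 3 (0.62 log units; beyond the scatter) and the step of a 6.0-fold higher number from compound 2 to compound 3 (0.78 log units; beyond the scatter) both show that replacing a hydroxyl-bearing group on the same aromatic carbon with methoxycarbonyl raises the number, whereas the step of a 1.4-fold lower number from compound 1 to compound 2 (0.16 log units; within the scatter) lies within the scatter.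

Compound 4, `CCCC[S+]([O-])c1sc2nc(-c3nccs3)cc(-c3ccc(CNC(C)=O)cc3)c2c1N`, differs from compound 3 in one place: acetamidomethyl in place of methoxycarbonyl on an aromatic carbon. For the measured compounds named here, the two measured steps that bear on this change point the same way: the methoxycarbonyl of compound 3 is the only group among the three that gives a clearly higher number, and the entering acetamidomethyl restores a hydrogen-bond donor, as compounds 1 and 2 carry. Compound 4 is therefore expected to give a lower number in this assay, close to compounds 1 and 2, with an estimated step of a 3.8-fold lower number from compound 3 to compound 4 (0.58 log units; beyond the scatter), giving an estimate of 4 nM with a range from 1.5 nM to 12 nM.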

Compound 4, half-maximal inhibitory concentration: 2.5 nM
Compound 4: the middle estimate sits 1.6-fold (0.20 log units) above what was measured; the range from low to high includes it.
By their numbers in this assay, from the lowest: compounds 2, 4 and 1 (each within the scatter of the next); then compound 3.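

For the compounds shown here, compound 4 shows that this place, para to a large group, does not need a hydroxyl-bearing group to give a low number in this assay: acetamidomethyl in place of methoxycarbonyl gives a 6.0-fold lower number from compound 3 to compound 4 (0.78 log units; beyond the scatter) and thus adds to the earlier comparisons a group with no hydroxyl. Against the hydroxyl-bearing groups, acetamidomethyl cannot be told apart, with no change at the digits printed from compound 2 to compound 4 (within the scatter) and a 1.4-fold lower number from compound 1 to compound 4 (0.16 log units; within the scatter) as the two steps. The higher number of compound 3 therefore does not go with heavy-atom count in this pair, since the entering group has 5 heavy atoms and the leaving group 4.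

On these data alone, whether an aminomethyl, a methoxymethyl or a carboxylic acid at this place would also give a low number stays open. Nothing shown explains these differences.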